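The source may hold more compounds than are shown below. What is called first, only, known or untested is meant among the compounds shown, and "the series" means these compounds.

Compounds measured in an assay for binding affinity to Alpha-1B adrenergic receptor (Homo sapiens) (on this read-out higher numbers stand for weaker inhibition and lower numbers for stronger inhibition), so far:

Compound 1 `CN1CCC[C@@H]1Cn1nc(Cc2ccc(O)cc2)c2ccccc2c1=O` gives 398 nM.
Compound 2 `CN1CCC[C@@H]1Cn1nc(Cc2ccc(F)cc2)c2ccccc2c1=O` gives 79.4 nM.

Compound 2 stands lowest of the two numbers in this assay; its nearest neighbour is compound 1, and the step between them is a 5.0-fold lower number from compound 1 to compound 2 (0.70 log units; beyond the scatter), a change of fluoro in place of hydroxy on an aromatic carbon.

Compound 3 `CCCCCc1nn(C[C@H]2CCCN2C)c(=O)c2ccccc12` is not yet measured in this assay. Against compound 2 the change is butyl in place of 4-fluorophenyl on a saturated chain carbon bound to an aromatic carbon; read one bond further out it is 4-fluorobenzyl to pentyl. Among the measured compounds shown here, the only measured step, from compound 1 to compound 2, keeps the aromatic ring and alters a single substituent on it, so it does not bear on the removal of that ring. Nothing in the measured pairs shows how this assay responds to a chain in place of the ring. The expectation is therefore a wide one: a step of a 3.1-fold higher number from compound 2 to compound 3 (0.50 log units; beyond the scatter) is estimated, with no firm direction beyond the scatter, the middle set somewhat higher than compound 2. Compound 3 is expected to give 250 nM, within 50 nM to 1300 nM.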

Compound 3, inhibition constant: 1000 nM
Compound 3: the middle estimate sits 4.0-fold (0.60 log units) below what was measured, within the range that was stated.
By their numbers in this assay, from the lowest: compound 2; then compound 1; then compound 3.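

In this assay, the step from 4-fluorophenyl to butyl on a saturated chain carbon bound to an aromatic carbon gives a 13-fold higher number from compound 2 to compound 3 (1.10 log units; beyond the scatter). Among the compounds shown here, this is the first reading at this position without an aromatic ring, as the earlier pair changed only a substituent on that ring. The same replacement starting from 4-hydroxyphenyl gives a 2.5-fold higher number from compound 1 to compound 3 (0.40 log units; beyond the scatter), so in these three compounds the butyl compound has the highest number, and both ring-bearing compounds, with either hydroxy or fluoro on the ring, lie lower; no available evidence accounts for this difference.

The compounds shown do not separate the loss of the aromatic ring from the change of group size, since a saturated cyclohexyl ring or a longer chain such as heptyl would be needed to tell those two readings apart. Also open, on these data alone, is whether other groups on the ring, such as chloro, methoxy or an amine, or a pyridine ring in place of the phenyl, would take the number below that of compound 2 at 79.4 nM.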